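From Saturated Amine Ring to Aromatic Ether

The compounds below may be only part of what the source reports. "The series", "measured", "known", "first", "only" and "open" are said of these compounds alone.

Among the measured compounds shown here, compound 2 `C=C1C(=O)O[C@@H]2CC(C)=C([C@@H](C)CCCOC(C)=O)[C@@H](OC(=O)CN3CCCCC3)[C@H]12` is one of two compounds measured in a functional assay on HeLa cells (Homo sapiens) for cytotoxicity, read by sulforhodamine B assay, with a stated time of 72 h; a lower number here means a stronger inhibitor, a higher number a weaker inhibitor; compound 2 gives 10300 nM, while compound 1 `C=C1C(=O)O[C@@H]2CC(C)=C([C@@H](C)CCCOC(C)=O)[C@@H](OC(=O)CN3CCCC3)[C@H]12` gives 12700 nM. The step of a 1.2-fold lower number from compound 1 to compound 2 (0.09 log units; within the scatter), so compound 2 has the lower number of the two without standing apart from compound 1. The change to compound 3 `C=C1C(=O)O[C@@H]2CC(C)=C([C@@H](C)CCCOC(C)=O)[C@@H](OC(=O)COc3cccc4cccnc34)[C@H]12` is (quinolin-8-yl)oxy in place of piperidin-1-yl on a saturated chain carbon bound to a carbonyl carbon. For the measured compounds named here, the one measured step swaps one six-membered non-aromatic ring with a hetero atom for another of the same kind, and it stayed within the scatter; it does not show how an aromatic ether at this place will behave. Going by the values given here, no measured step puts an aromatic group on this saturated chain carbon, so the expectation rests on the closeness of the two known numbers. Compound 3 is expected to give about 8000 nM, with a range from 2500 nM to 25000 nM, a step of a 1.3-fold lower number from compound 2 to compound 3 (0.11 log units; within the scatter) that is itself expected to stay within the scatter.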

Compound 3, half-maximal inhibitory concentration: 8940 nM
Compound 3: middle estimate off by 1.1-fold (0.05 log units), on the low side; the range from low to high includes it.
By their numbers in this assay, from the lowest: compounds 3, 2 and 1 (each within the scatter of the next).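

In this assay, putting (quinolin-8-yl)oxy in place of piperidin-1-yl on a saturated chain carbon bound to a carbonyl carbon gives a 1.2-fold lower number from compound 2 to compound 3 (0.06 log units; within the scatter), and putting it in place of pyrrolidin-1-yl gives a 1.4-fold lower number from compound 1 to compound 3 (0.15 log units; within the scatter). The earlier step only exchanged one saturated amine ring for another, whereas these steps bring in an aromatic ether with two aromatic rings and 11 heavy atoms in place of the 6 of piperidin-1-yl. Even so, neither step moves beyond the scatter, so this much larger change at this place leaves the three compounds unseparated in this assay.

No supporting data explain why the numbers stay so close. Also open, on these data alone, is how a simple phenoxy group, an open-chain dimethylamino group or a carboxylic acid would behave at this place.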